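The source may hold more compounds than are shown below. What is called first, only, known or untested is meant among the compounds shown, and "the series" means these compounds.

Three compounds, compound 1 `O=C(CCc1ccccc1)Nc1cc2nc(C3CCCCC3)[nH]c2cc1N1CCCC1`, compound 2 `O=C(Nc1cc2nc(C3CCCCC3)[nH]c2cc1N1CCCC1)c1ccccc1` and compound 3 `O=C(NCc1ccccc1)Nc1cc2nc(C3CCCCC3)[nH]c2cc1N1CCCC1`, share one core and differ only in the group on the amide carbonyl. In an ADME assay on Vero cells (Chlorocebus sabaeus) for cytotoxicity, read by resazurin assay, with a stated time of 3 days (a higher number here means a weaker inhibitor, a lower number a stronger inhibitor), compound 1 gives > 100 ug/mL, which is a limit of the assay rather than a number. Compound 2 gives > 100 ug/mL in this assay, again a limit. Compound 3 gives > 100 ug/mL in this assay, also a limit. The steps a step that the two limits leave unreadable from compound 1 to compound 2, a step that the two limits leave unreadable from compound 1 to compound 3 and a step that the two limits leave unreadable from compound 2 to compound 3 stay unreadable because of the limit of > 100 ug/mL in this assay, at which 3 of the 3 values shown sit.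

The next compound, compound 4 `CCCCNC(=O)Nc1cc2nc(C3CCCCC3)[nH]c2cc1N1CCCC1`, differs from compound 3 by propyl in place of phenyl on a saturated chain carbon bound to an amide-type nitrogen. Among the measured compounds shown here, no measured step gives a readable size for this change. Compound 4 is therefore expected to give 100 ug/mL in this assay, within 50 ug/mL to 200 ug/mL. The expected step of a number no higher from compound 3 to compound 4 (the limit leaves the size open) is none beyond the scatter.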

Compound 4, half-maximal inhibitory concentration: > 100 ug/mL
Compound 4 was reported as a limit; the forecaster's own chance of this, stated with the estimate: 80%; the middle value lies on the limit itself.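

Compound 4 adds no readable step to compound 1, compound 2 or compound 3, because all four stop at the same limit: the limit of > 100 ug/mL in this assay, at which 4 of the 4 values shown sit. What number any of these compounds would give in this assay, and how the group on the carbonyl would shift it, stays open.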